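This account rests on a few compounds, and the source may have more. Where it says the series, first, only, none or still open, it means among the compounds named here.

For the measured compounds named here, compound 2 `O=C(NO)c1ccc(Cn2ccc3cc(C(=O)c4ccc(Cl)cc4)ccc32)cc1` is one of two compounds measured in an assay on isolated protein for inhibition of histone deacetylase 8 (Homo sapiens); on this read-out higher numbers stand for weaker inhibition and lower numbers for stronger inhibition. Compound 2 gives 1060 nM, and compound 1 `COc1ccc(C(=O)c2ccc3c(ccn3Cc3ccc(C(=O)NO)cc3)c2)cc1` gives 646 nM. The gap between them, a 1.6-fold higher number from compound 1 to compound 2 (0.22 log units; within the scatter), lies within the scatter, so the two numbers cannot be told apart. Compound 3 `Cc1ccc(C(=O)c2ccc3c(ccn3Cc3ccc(C(=O)NO)cc3)c2)cc1` is compound 2 with methyl in place of chloro on an aromatic carbon. Going by the values given here, the only measured step that bears on this change is the earlier swap at the same aromatic carbon, where a 1.6-fold higher number from compound 1 to compound 2 (0.22 log units; within the scatter) stayed within the scatter. Among the compounds with values here, no compound carrying a methyl at that place has been measured, so there is no direct precedent for it. For compound 3 the expected step is a 1.2-fold lower number from compound 2 to compound 3 (0.07 log units; within the scatter), which is not beyond the scatter. Compound 3 is therefore estimated to give 900 nM in this assay, with a likely range from 450 nM to 1800 nM.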

Compound 3, half-maximal inhibitory concentration: 1490 nM
Estimate against measurement, compound 3: 1.7-fold (0.22 log units) below; the measured number falls inside the stated range.
By their numbers in this assay, from the lowest: compounds 1, 2 and 3 (each within the scatter of the next, the first and the last beyond it).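

In this assay, methyl in place of chloro on this aromatic carbon gives a 1.4-fold higher number from compound 2 to compound 3 (0.15 log units; within the scatter), so these two groups cannot be told apart here. Methyl in place of methoxy at the same carbon gives a 2.3-fold higher number from compound 1 to compound 3 (0.36 log units; beyond the scatter), the first single change at this place to pass the scatter; it is a modest step, but it shows that the group here can shift the number, with methoxy on the stronger side of methyl. The data at hand offer no measured explanation for this difference.

Still open, as far as these compounds go, is how far the number moves with groups of another kind at this carbon, such as an amine, a carboxylic acid or a longer chain. Also open, from the compounds shown here alone, is whether methoxy would keep its edge over methyl on a different carbon of the same ring.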